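This account rests on a few compounds, and the source may have more. Where it says the series, first, only, none or still open, it means among the compounds named here.

Measured so far:
compound 1 `Cc1cccc(-c2noc(C3CN(S(=O)(=O)c4cccc(C)c4)C3)n2)c1`; in an assay on HEK293 cells for positive allosteric modulation of metabotropic glutamate receptor 5 (Homo sapiens), read by FLIPR (a lower number here means that less compound is needed, a higher number that more compound is needed for the effect), compound 1 gives > 10000 nM, which is a limit of the assay and not a number.
compound 2 `Cc1cccc(S(=O)(=O)N2CC(c3nc(-c4cccc(Cl)c4)no3)C2)c1`; in this assay compound 2 gives > 10000 nM, again a limit of the assay.
compound 3 `Cc1cccc(-c2noc(C3CN(C(=O)c4ccccc4F)C3)n2)c1`; in this assay compound 3 gives > 10000 nM, also a limit of the assay.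

Compound 1 and compound 2 differ in one place: chloro in place of methyl on an aromatic carbon. Both values are limits, so the step that the two limits leave unreadable from compound 1 to compound 2 cannot be read in size or direction. Going by the values given here, compound 3 differs from compound 1 in more than one place; the difference between the two cores is not broken down here, and the pair gives no step, only two values that are both limits.

Compound 4 `O=C(c1ccccc1F)N1CC(c2nc(-c3cccc(Cl)c3)no2)C1` has not yet been measured in this assay. It differs from compound 3 by chloro in place of methyl on an aromatic carbon, the same change as from compound 1 to compound 2 and at the same place, since the two place descriptions agree word for word.

What can be expected for compound 4 rests on little. Among the compounds with values here, the only precedent for this change left nothing readable, and every value so far sits at the assay limit (the limit of > 10000 nM in this assay, at which 3 of the 3 values shown sit). The step that the limit leaves unreadable from compound 3 to compound 4 is therefore expected to be small, with no basis for a gain. Compound 4 is expected to give about 15000 nM in this assay, estimated between 7000 nM and 50000 nM, and most likely to be reported once more as a limit rather than a number.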

Compound 4, half-maximal effective concentration: > 10000 nM
Compound 4: no number, only a limit; the forecaster's own chance of this, stated with the estimate: 85%; the middle value does not contradict the limit.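

No new step can be read from compound 3 to compound 4 in this assay: both results are limits and not numbers, so the change from 3-methylphenyl to 3-chlorophenyl has no readable size or direction. The whole set gives the same reading: the limit of > 10000 nM in this assay, at which 4 of the 4 values shown sit. The compounds shown leave open whether any structure in this series gives a numerical value in this assay.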